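The source may report more compounds than this note shows. Statements on the series, on what has been measured and on what is new or still open speak of the compounds shown alone.

In a functional assay on NCI-H460 cells (Homo sapiens) for inhibition, read by MTT assay, with a stated time of 48 h (a higher number here means a weaker inhibitor, a lower number a stronger inhibitor), compound 1 `O=C(CC(c1ccccc1)C(C(=O)Nc1ccccn1)C(=O)Nc1ccccn1)c1ccccc1` is reported as "not active" (no number reported), with no number attached. Among the measured compounds shown here, compound 2 `O=C(CC(c1ccc(Cl)cc1)C(C(=O)Nc1ccccn1)C(=O)Nc1ccccn1)c1ccccc1` gives 18900 nM, the only number so far, so there is no other value to rank it against. Compound 3 `O=C(CC(c1c(Cl)cccc1Cl)C(C(=O)Nc1ccccn1)C(=O)Nc1ccccn1)c1ccccc1` differs from compound 2 by one change, a 2,6-dichlorophenyl in place of 4-chlorophenyl on a saturated chain carbon bound to two saturated chain carbons. For the measured compounds named here, no measured step is available as a guide, so the expected step of a 1.3-fold lower number from compound 2 to compound 3 (0.10 log units; within the scatter) is small and no larger than the usual scatter of this assay. The estimated value for compound 3 is 15000 nM, with an expected range of 5000 nM to 50000 nM.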

Compound 3, half-maximal inhibitory concentration: 27400 nM
The estimate for compound 3 lay 1.8-fold (0.26 log units) below the measured number; measured number inside the range.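

In this assay, a 1.4-fold higher number from compound 2 to compound 3 (0.16 log units; within the scatter) shows that 2,6-dichlorophenyl and 4-chlorophenyl cannot be told apart on this saturated chain carbon. Among the compounds shown here, this is the first numerical comparison at this position, and adding a second chlorine and moving the chlorine atoms leaves the two values within the scatter. Nothing available explains this result.

Steps to compound 1 cannot be read, as it has no number. On these data alone, whether a methoxy group, an amine or a carboxylic acid on this phenyl ring would give a lower number remains open.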